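The compounds below may be only part of what the source reports. "The series", "measured", "known", "first", "only" and "open" are said of these compounds alone.

Working notes on the series. In an ADME assay on cells (Hepatocyte, Mus musculus) for cytotoxicity, read by MTT assay, with a stated time of 24 h (on this read-out higher numbers stand for lower toxicity in this test and lower numbers for higher toxicity in this test), compound 3 (`O=S(=O)(c1ccccc1)n1c(-c2cn(-c3ccccc3)nc2-c2ccc(F)cc2)nc2ccccc21`) gives 231000 nM and so sits level with compound 2 (`Cc1ccc(-c2nn(-c3ccccc3)cc2-c2nc3ccccc3n2S(=O)(=O)c2cc(C)ccc2C)cc1`) at 231000 nM at the digits shown. Compound 1 (`Cc1ccc(-c2nn(-c3ccccc3)cc2-c2nc3ccccc3n2S(=O)(=O)c2ccccc2)cc1`) gives 189000 nM and lies within the scatter of both.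

The next step leads to compound 4 (`Cc1ccc(C)c(S(=O)(=O)n2c(-c3cn(-c4ccccc4)nc3-c3ccc(F)cc3)nc3ccccc32)c1`), which carries 2,5-dimethylphenyl in place of phenyl on a sulfonyl sulfur. Both measured steps bear on this. The same exchange, made on compound 1, gave a 1.2-fold higher number from compound 1 to compound 2 (0.09 log units; within the scatter) and stayed within the scatter. Fluoro in place of methyl on an aromatic carbon, the change that separates compound 3 from compound 1, gave a 1.2-fold higher number from compound 1 to compound 3 (0.09 log units; within the scatter) and also stayed within the scatter.

The exchange has been measured only once, and not yet on a compound carrying the fluoro, so the basis is thin. Even so, neither measured step gives grounds to expect a real shift, and no step beyond the scatter is expected in this assay for this change. The estimated step is a 1.1-fold higher number from compound 3 to compound 4 (0.03 log units; within the scatter) and is expected to remain within the scatter. For compound 4 the estimate is 250000 nM (expected range 130000 nM to 450000 nM).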

Compound 4, half-maximal cytotoxic concentration: 122000 nM
Estimate against measurement, compound 4: 2.0-fold (0.31 log units) above; the whole stated range lies above it.
By their numbers in this assay, from the lowest: compounds 4, 1, 2 and 3 (each within the scatter of the next).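

In this assay, the exchange of phenyl for 2,5-dimethylphenyl on a sulfonyl sulfur whose other neighbours are aromatic nitrogen can now be read on a second core, a 1.9-fold lower number from compound 3 to compound 4 (0.28 log units; within the scatter), and the two readings of this change do not separate: the same change on two cores in this assay, a 1.2-fold higher number (0.09 log units; within the scatter) from compound 1 to compound 2 and a 1.9-fold lower number (0.28 log units; within the scatter) from compound 3 to compound 4, 2.3-fold (0.36 log units) apart, within the scatter of two such steps

Fluoro in place of methyl on an aromatic carbon can likewise now be read with 2,5-dimethylphenyl on the sulfonyl sulfur, a 1.9-fold lower number from compound 2 to compound 4 (0.28 log units; within the scatter), and its two readings do not separate either: the same change on two cores in this assay, a 1.2-fold higher number (0.09 log units; within the scatter) from compound 1 to compound 3 and a 1.9-fold lower number (0.28 log units; within the scatter) from compound 2 to compound 4, 2.3-fold (0.36 log units) apart, within the scatter of two such steps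

The two readings of each change differ in sign, but that difference carries no weight at this size, so neither change has yet been shown to move this read-out on either core.

The compounds shown hold only phenyl and 2,5-dimethylphenyl on the sulfonyl sulfur, so it remains open whether an amine or a longer alkyl chain in that place would give a step beyond the scatter. At the other site, only methyl and fluoro are shown, which leaves open how a nitrile or a carboxylic acid on that aromatic carbon would read.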